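This account rests on a few compounds, and the source may have more. Where it says the series, first, only, none or still open, it means among the compounds named here.

Compound 1 `Cc1ccc2nc(-c3ccc(Cl)cc3)cc(C(=O)OCc3ccccc3)c2c1` in a functional assay on MDA-MB-231 cells (Homo sapiens) for antiproliferative activity, read by MTT assay, with a stated time of 48 h (a higher number here means a weaker inhibitor, a lower number a stronger inhibitor), gives > 100000 nM, a limit of the assay.
Compound 2 `COc1ccc(-c2cc(C(=O)OCc3ccccc3)c3cc(C)ccc3n2)cc1` in this assay gives 20500 nM.
Compound 3 `O=C(OCc1ccccc1)c1cc(-c2ccc(Cl)cc2)nc2cc(Cl)c(Cl)cc12` in this assay gives > 100000 nM, a limit of the assay.

Compound 1 and compound 2 share a core and differ in one place, (methoxy in place of chloro on an aromatic carbon). This change gave an at least 4.8-fold lower number from compound 1 to compound 2 (0.68 log units; beyond the scatter). Two of the three values shown sit at the limit of > 100000 nM in this assay, at which 2 of the 3 values shown sit, so the step is known only as a lower bound.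

Compound 3 carries a different core; the difference between the two cores is not broken down here. Compound 4 `COc1ccc(-c2cc(C(=O)OCc3ccccc3)c3cc(Cl)c(Cl)cc3n2)cc1`, not yet measured, stands to compound 3 as compound 2 stands to compound 1: methoxy in place of chloro on an aromatic carbon. The place lines read alike, so this is the same kind of change. Because compound 3 gives > 100000 nM as a limit, and because the earlier step gave an at least 4.8-fold lower number from compound 1 to compound 2 (0.68 log units; beyond the scatter), compound 4 is expected to show an at least 2.8-fold lower number from compound 3 to compound 4 (0.45 log units; beyond the scatter). The estimate for compound 4 in this assay is 35000 nM, between 8000 nM and 150000 nM.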

Compound 4, half-maximal inhibitory concentration: 39200 nM
Compound 4: middle estimate off by 1.1-fold (0.05 log units), on the low side; measured number inside the range.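

In this assay, methoxy in place of chloro on an aromatic carbon again gave a lower number, an at least 2.5-fold lower number from compound 3 to compound 4 (0.40 log units; beyond the scatter), so the direction of the change held on both cores shown. This does not give the true size of either step, nor does it show whether the change is worth the same on the two cores: the same change on two cores in this assay, an at least 4.8-fold lower number (0.68 log units; beyond the scatter) from compound 1 to compound 2 and an at least 2.5-fold lower number (0.40 log units; beyond the scatter) from compound 3 to compound 4; the limit leaves it open whether they differ. Neither chloro compound offers a number to start from, only a limit: the limit of > 100000 nM in this assay, at which 2 of the 4 values shown sit.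

The compounds shown leave open whether an amine or a hydroxyl in place of the methoxy would carry the number lower still. They also leave open how an amide in place of the ester would behave on either core.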